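The source may hold more compounds than are shown below. What is called first, only, known or untested is meant among the compounds shown, and "the series" means these compounds.

Going by the values given here, compound 1 `CC#CC(CC(=O)O)c1ccc(OCC2COc3ccc(Cl)cc3O2)cc1` was tested in a functional assay on HEK293 cells for agonist activity at Free fatty acid receptor 1 (Homo sapiens), read by fluorescence and calcium flux, with a stated time of 10 min (a higher number here means a larger maximal response, a lower number a smaller maximal response), where compound 1 reaches 104%, the highest of the three numbers measured so far. Compound 2 `Cn1nncc1C(CC(=O)O)c1ccc(OCC2COc3ccc(Cl)cc3O2)cc1`, in which a 1-methyl-1H-1,2,3-triazol-5-yl group stands in place of the prop-1-yn-1-yl group, reaches 70%, and compound 3 `Cn1cncc1C(CC(=O)O)c1ccc(OCC2COc3ccc(Cl)cc3O2)cc1`, with a 1-methyl-1H-imidazol-5-yl group there, reaches 62%. The two exchanges give large drops: a number 34 percentage points lower from compound 1 to compound 2 (beyond the scatter) and a number 42 percentage points lower from compound 1 to compound 3 (beyond the scatter), while a number 8 percentage points lower from compound 2 to compound 3 (within the scatter) stays within the scatter.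

Compound 4 `CC#C[C@@H](CC(=O)O)c1ccc(OC[C@@H]2COc3ccc(Cl)cc3O2)cc1` keeps every atom and bond of compound 1; the difference is the two compounds have the same atoms and bonds; at least one stereo element is drawn with a configuration in one of them and without one in the other: 2 of 2 stereo elements differ; a stereocentre at a saturated chain carbon is drawn without a configuration in compound 1 and S in compound 4; a stereocentre at a saturated ring carbon is drawn without a configuration in compound 1 and R in compound 4. Among the compounds with values here, none of the measured steps touches a stereo element: all three swap the group on the saturated chain carbon. Within the data shown here, there is therefore no measured step that bears directly on this change, and nothing suggests the maximal response should move beyond the scatter. Compound 4 is expected to reach 105%, within 90% to 120%, which means an estimated step of a number 1 percentage points higher from compound 1 to compound 4 (within the scatter).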

Compound 4, largest response reached (Emax), in percent of the reference or control that the assay uses: 65%
Estimate against measurement, compound 4: 40 percentage points above; the whole stated range lies above it.
By their numbers in this assay, from the lowest: compounds 3, 4 and 2 (each within the scatter of the next); then compound 1.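

Giving the same atoms and bonds a defined configuration is enough to move the maximal response in this assay, with a step of a number 39 percentage points lower from compound 1 to compound 4 (beyond the scatter). The earlier compounds shown here showed large steps only when the prop-1-yn-1-yl group on the saturated chain carbon was exchanged for another group, whereas here no group leaves or enters and the step is still large. So the drawn configuration counts at this part of the structure, not only the identity of the group, and the step can be tied to one thing alone: the fact that one of compounds 1 and 4 is drawn with a defined configuration and the other without, at the place where they differ.

The compounds shown leave open which of the two stereocentres, the chain carbon or the ring carbon, carries this step, and what the other configurations at them give. Also open, from the compounds shown here alone, is how a cyclopropyl group on the saturated chain carbon would behave in a defined configuration.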